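A few compounds are considered here, and "the series" means these few. Any claim that something is new, unique, unknown or untested is made for them only; others in the source may bear on it.

Two related compounds set the scene for this small comparison. In a functional assay on HL-60 cells (Homo sapiens) for cytotoxicity, read by MTT assay, with a stated time of 72 h (on this read-out lower numbers stand for stronger inhibition and higher numbers for weaker inhibition), compound 2 (`CCOC(=O)c1sc2ccccc2c1Nc1cc(OC)c(OC)c(OC)c1`) gives 5490 nM, and compound 1 (`COC(=O)c1sc2c(C)cccc2c1Nc1cc(OC)c(OC)c(OC)c1`) gives 4270 nM. These two numbers lie within the usual scatter of each other, so compound 2 stands level with compound 1 on the data available, and neither can be ranked over the other.

Compound 3 (`CCOC(=O)c1sc2cccc(C)c2c1Nc1cc(OC)c(OC)c(OC)c1`) is compound 2 with a single change: methyl in place of hydrogen on an aromatic carbon. In words, this is methyl in place of hydrogen on an aromatic carbon, in a six-membered aromatic ring of carbon only, ortho to a fused ring and meta to a fused ring. The rest of the molecule stays the same.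

Among the measured compounds shown here, no pair of measured compounds isolates this change, so the data offer no direct guide to its size or direction. The expectation is therefore cautious, with no shift beyond the scatter and only a slight lean towards a lower number. The expected step of a 1.6-fold lower number from compound 2 to compound 3 (0.20 log units; within the scatter) is correspondingly modest. In this assay, the estimate for compound 3 is 3500 nM, with an expected range of 900 nM to 12000 nM.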

Compound 3, half-maximal inhibitory concentration: 7390 nM
For compound 3 the middle estimate is 2.1-fold (0.32 log units) below the measured one; the range from low to high includes it.
By their numbers in this assay, from the lowest: compounds 1, 2 and 3 (each within the scatter of the next).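

Among the compounds shown here, the step of a 1.3-fold higher number from compound 2 to compound 3 (0.13 log units; within the scatter) in this assay is the first direct reading of methyl in place of hydrogen on this aromatic carbon, ortho to a fused ring and meta to a fused ring. It shows that this added carbon, at this one position, leaves compound 3 level with compound 2, with no difference that can be told apart from ordinary repeat variation in the measurement. Nothing measured here gives a reason for this result.

As far as these compounds go, one small group says little about how far this position can be changed, so it stays open whether a longer chain such as propyl, an amine or a carboxylic acid on the same carbon would give a number clearly apart from that of compound 2. From the compounds shown here alone, compound 1 differs from compound 2 and from compound 3 in more than one place, so those steps cannot be read, and how a methyl on another carbon of this ring compares also remains unknown.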